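The compounds below may be only part of what the source reports. "The series", "measured", "known", "first", "only" and "open" are said of these compounds alone.

Compound 1 `CC(=O)N[C@@H](CSC(=S)Nc1cccc(NC(=S)SC[C@H](NC(C)=O)C(=O)O)c1)C(=O)O` was tested in a functional assay on LoVo/DX cells (Homo sapiens) for antiproliferative activity, read by sulforhodamine B assay, with a stated time of 72 h; a higher number here means a weaker inhibitor, a lower number a stronger inhibitor. In this assay compound 1 gives > 25000 nM, which is a limit of the assay rather than a number. Compound 2 `CC(=O)N[C@@H](CSC(=S)Nc1ccc(C)c(NC(=S)SC[C@H](NC(C)=O)C(=O)O)c1)C(=O)O` differs from compound 1 by methyl in place of hydrogen on an aromatic carbon and in this assay compound 2 gives 22400 nM; the step of an at least 1.1-fold lower number from compound 1 to compound 2 (0.04 log units; that floor lies within the scatter) can only be given as a floor because of the limit of > 25000 nM in this assay, at which 1 of the 3 values shown sits. Compound 3 `S=C=Nc1cccc(N=C=S)c1` has a different core, and the difference between the two cores is not broken down here; in this assay compound 3 gives 55700 nM. Compound 4 `Cc1ccc(N=C=S)cc1N=C=S` arises from compound 3 by methyl in place of hydrogen on an aromatic carbon, the same kind of change as from compound 1 to compound 2, though here the methyl sits ortho and para to a group of 3 heavy atoms rather than to a large group. Because the earlier step of an at least 1.1-fold lower number from compound 1 to compound 2 (0.04 log units; that floor lies within the scatter) lies within the scatter, the step of a 1.4-fold lower number from compound 3 to compound 4 (0.14 log units; within the scatter) is expected to be small. Compound 4 is estimated at 40000 nM, between 18000 nM and 90000 nM.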

Compound 4, half-maximal inhibitory concentration: 47300 nM
Compound 4: the middle estimate sits 1.2-fold (0.07 log units) below what was measured; the range from low to high includes it.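

In this assay, methyl in place of hydrogen on an aromatic carbon gives a 1.2-fold lower number from compound 3 to compound 4 (0.07 log units; within the scatter), so on this core the change stays within the usual scatter of repeated measurements. Set side by side, the two cores read as follows: the same change on two cores in this assay, an at least 1.1-fold lower number (0.04 log units; that floor lies within the scatter) from compound 1 to compound 2 and a 1.2-fold lower number (0.07 log units; within the scatter) from compound 3 to compound 4; the limit leaves it open whether they differ. This does not show that the change carries over with exactly the same size, since the step from compound 1 is only a floor: the limit of > 25000 nM in this assay, at which 1 of the 4 values shown sits.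

The compounds shown leave open whether another group on the same aromatic carbon, such as an ethyl group, a methoxy group or an amine, would give a step beyond the scatter. They also leave open what the methyl would do on a further core.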